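The source may report more compounds than this note shows. Statements on the series, on what has been measured and on what is new or still open speak of the compounds shown alone.

Compound 1, `CCC[C@@H](OC(C)=O)C1=C(Br)/C(=C/Br)OC1=O`: in a functional assay on ZR-75-1 cells (Homo sapiens) for cytotoxicity (a higher number here means that more compound is needed for the effect, a lower number that less compound is needed), compound 1 gives 1.6 ug/mL.
Compound 2, `CCC[C@@H](OC(C)=O)C1=C(Br)[C@@](OC)(C(Br)Br)OC1=O`: compound 2 gives 2.8 ug/mL.
Compound 3, `CCC[C@@H](OC(C)=O)C1=C(Br)[C@](OC)(C(Br)Br)OC1=O`: compound 3 gives 3.8 ug/mL.

Compound 2 has the second highest of the three numbers, but both neighbours lie within the usual scatter of it: compound 1 with a lower number and compound 3 with a higher one. Going by the values given here, the one measured step between close relatives, a 1.4-fold higher number from compound 2 to compound 3 (0.13 log units; within the scatter), stays within the scatter, and the pair differs only in how one stereocentre is drawn, as noted in the fact that compounds 2 and 3 differ only in the configuration as drawn. The shared core thus tolerates a change of configuration without a visible shift in the read-out.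

Compound 4, `CCC[C@@H](OC(C)=O)C1=C(Br)[C@](C)(OC)OC1=O`, is reached from compound 2 by a different kind of change: methyl in place of dibromomethyl on a saturated ring carbon. Among the compounds with values here, none of the measured steps swaps one group for another at this position, so there is no directly comparable step to lean on; the only measured step concerns configuration and is small. Two bromine atoms leave the molecule, which is a larger change than anything measured here, so a step beyond the scatter cannot be ruled out. The expected step is a 2.1-fold higher number from compound 2 to compound 4 (0.33 log units; beyond the scatter), leaning toward a higher number. Compound 4 is estimated at 6 ug/mL, within a range from 2 ug/mL to 20 ug/mL.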

Compound 4, concentration for half-maximal effect: 4 ug/mL
Beside the measured number, compound 4's estimate is 1.5-fold (0.18 log units) above it, within the range that was stated.
By their numbers in this assay, from the lowest: compounds 1, 2, 3 and 4 (each within the scatter of the next, the first and the last beyond it).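

In this assay, putting methyl in place of dibromomethyl on this saturated ring carbon gives a 1.4-fold higher number from compound 2 to compound 4 (0.15 log units; within the scatter) and so leaves the read-out within the usual scatter, even though two bromine atoms leave the molecule. The earlier compounds shown here showed only that the drawn configuration at this carbon could differ without a visible shift; compound 4 adds that the group on this carbon can also be exchanged for a much smaller one, at least in this single case, with no visible shift. Nothing given here explains why this exchange leaves the number within the scatter, and the one available structural fact concerns configuration, not this change of group.

From the compounds shown here alone, what an amine, a carboxylic acid, bromomethyl or a longer chain such as butyl would do on this same carbon remains open, so one exchange does not yet define how much this position tolerates. Also open, going by these compounds, is whether a methyl compound drawn with the opposite configuration at this carbon would stay as close to compound 4 as compound 3 stays to compound 2.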